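Trifluoromethylphenyl to aminophenyl on the cyclopentane carbon

A few compounds are considered here, and "the series" means these few. Any claim that something is new, unique, unknown or untested is made for them only; others in the source may bear on it.

Three ureas sharing one core have been measured in an assay on microsomes for inhibition of acyl-CoA:cholesterol acyltransferase (Oryctolagus cuniculus); a higher number here means a weaker inhibitor, a lower number a stronger inhibitor. Compound 1 `Cc1ccccc1C1(CNC(=O)Nc2c(C(C)C)cccc2C(C)C)CCCC1` gives 17 nM, compound 2 `CC(C)c1cccc(C(C)C)c1NC(=O)NCC1(c2ccc(Cl)cc2)CCCC1` gives 32 nM, and compound 3 `CC(C)c1cccc(C(C)C)c1NC(=O)NCC1(c2ccc(C(F)(F)F)cc2)CCCC1` gives 66 nM, which makes compound 3 the highest number of the three. The steps that separate them are a 1.9-fold higher number from compound 1 to compound 2 (0.27 log units; within the scatter), a 3.9-fold higher number from compound 1 to compound 3 (0.59 log units; beyond the scatter) and a 2.1-fold higher number from compound 2 to compound 3 (0.31 log units; beyond the scatter).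

Compound 4 `CC(C)c1cccc(C(C)C)c1NC(=O)NCC1(c2cccc(N)c2)CCCC1` differs from compound 3 in one place: 3-aminophenyl in place of 4-(trifluoromethyl)phenyl on a saturated ring carbon. The measured steps that bear on this are the exchanges of the aryl group on the same saturated ring carbon, all of which stayed modest, and the swap on the aromatic carbon from compound 2 to compound 3. Among the measured compounds shown here, no measured compound carries an aminophenyl, so the direction of this change is not directly fixed by the data. Given the narrow spread of the three measured values in this assay, compound 4 is expected to land near the middle of that spread, with a step of a 1.7-fold lower number from compound 3 to compound 4 (0.22 log units; within the scatter). The estimate for compound 4 is therefore 40 nM, within a range from 10 nM to 160 nM.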

Compound 4, half-maximal inhibitory concentration: 21 nM
Compound 4: the middle estimate sits 1.9-fold (0.28 log units) above what was measured; the measured number falls inside the stated range.
By their numbers in this assay, from the lowest: compounds 1, 4 and 2 (each within the scatter of the next); then compound 3.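

In this assay, 3-aminophenyl in place of 4-(trifluoromethyl)phenyl on a saturated ring carbon gives a 3.1-fold lower number from compound 3 to compound 4 (0.50 log units; beyond the scatter), so this position accepts an aryl group carrying an amine and the swap moves the number beyond the scatter. The other two exchanges stay within the scatter, at a 1.5-fold lower number from compound 2 to compound 4 (0.18 log units; within the scatter) and a 1.2-fold higher number from compound 1 to compound 4 (0.09 log units; within the scatter), which places the aminophenyl compound alongside the 2-methylphenyl and 4-chlorophenyl compounds and leaves compound 3 alone at the high end. Nothing measured here accounts for this step.

Going by these compounds, this single exchange changes both the group and its position, so it remains open whether a 4-aminophenyl or a 3-(trifluoromethyl)phenyl would read like compound 4 or like compound 3. Also open, on these data alone, is how a dimethylamino or acetamido group would compare with the free amine.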